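From hydroxy to methoxy on compound 1

The source may report more compounds than this note shows. Statements on the series, on what has been measured and on what is new or still open speak of the compounds shown alone.

Compound 1 `CC1(C)C2CCC1(C)C(OC(=O)/C=C/c1ccc(O)c(O)c1[N+](=O)[O-])C2`: 52900 nM
Compound 2 `CC1(C)C2CCC1(C)C(OC(=O)/C=C/c1ccc(O)c(O)c1)C2`: 19500 nM

Both values come from a functional assay on A549 cells (Homo sapiens) for cytotoxicity, read by MTT assay; on this read-out higher numbers stand for weaker inhibition and lower numbers for stronger inhibition. Compound 1 holds the higher of the two numbers, so it is the weaker inhibitor of this pair.

Compound 3 `COc1c(O)ccc(/C=C/C(=O)OC2CC3CCC2(C)C3(C)C)c1[N+](=O)[O-]` keeps the core of compound 1 and changes one place: methyl in place of hydrogen on an oxygen on an aromatic ring. In words, this is methyl in place of hydrogen on an oxygen on an aromatic ring, or hydroxy to methoxy.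

For the measured compounds named here, only one measured step is available for comparison, a 2.7-fold lower number from compound 1 to compound 2 (0.43 log units; beyond the scatter). It is modest and beyond the scatter, but it is a different change: hydrogen in place of nitro on an aromatic carbon. Going by the values given here, no measured pair shows hydroxy to methoxy, so this step offers only a rough scale for one small edit and gives no direction. A shift of about that size or smaller is therefore expected, and neither direction is favoured.

The expected step is a 1.1-fold lower number from compound 1 to compound 3 (0.02 log units; within the scatter), which would leave little clear change. For compound 3 the estimated value is 50000 nM, with an expected range from 20000 nM to 120000 nM.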

Compound 3, half-maximal inhibitory concentration: 21100 nM
Compound 3: middle estimate off by 2.4-fold (0.37 log units), on the high side; the range from low to high includes it.
By their numbers in this assay, from the lowest: compounds 2 and 3 (each within the scatter of the next); then compound 1.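

In this assay turning one hydroxy of compound 1 into methoxy gives a 2.5-fold lower number from compound 1 to compound 3 (0.40 log units; beyond the scatter) and so provides the first measured direction for this change: a single added methyl on this oxygen on an aromatic ring goes with stronger inhibition, beyond the scatter. For the compounds shown here, until now the only measured edit of compound 1 was the loss of its nitro, which gave a 2.7-fold lower number from compound 1 to compound 2 (0.43 log units; beyond the scatter) and likewise pointed towards stronger inhibition, so compound 1 now has two different single edits that each lower the number modestly. Nothing shown here bears on why the methyl has this effect.

The compounds shown leave open whether an ethyl or a longer chain on this same oxygen would extend the step or reverse it, and whether an amine in place of this hydroxy would act like the methoxy. They also leave open whether hydroxy to methoxy would give a similar step on compound 2, which carries hydrogen where compound 1 carries nitro, so the two edits cannot yet be said to add together.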